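This account rests on a few compounds, and the source may have more. Where it says the series, first, only, none or still open, it means among the compounds named here.

Compound 1, whose structure is `N#Cc1ccc(NC(=S)N/N=C/c2ccc3ccccc3n2)cc1`, was examined in a functional assay on HT-29 cells (Homo sapiens) for antiproliferative activity, read by sulforhodamine B assay, with a stated time of 72 h (on this read-out lower numbers stand for stronger inhibition and higher numbers for weaker inhibition), where compound 1 gives 15600 nM. Among the numbers recorded in this assay, compound 1 stands as the highest of the two, and the nearest to it is compound 3, with the structure `CN(C)C(=S)N/N=C/c1cc2cccnc2s1`, which in this assay gives 13400 nM; the gap between the two lies within the scatter of repeated measurements, so no order between them can be claimed. Compound 2, with the structure `Cc1ccc(NC(=O)N/N=C/c2ccc3ccccc3n2)cc1`, sits at the limit of > 100000 nM in this assay, at which 1 of the 3 values shown sits, and its entry of > 100000 nM in this assay is therefore a limit of the assay rather than a number.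

Compound 4, whose structure is `Fc1ccc(NC(=S)N/N=C/c2ccc3ccccc3n2)cc1`, has not yet been measured in this assay. It differs from compound 1 in a single place: fluoro in place of cyano on an aromatic carbon. Within the data shown here, none of the measured compounds differ from one another in exactly one place, so no measured step gives a precedent for this change. The step from compound 1 to compound 4 is expected to be small and of no clear direction, with a size of a 1.0-fold higher number from compound 1 to compound 4 (0.01 log units; within the scatter), that is, nothing beyond the scatter. Compound 4 is accordingly estimated to give 16000 nM in this assay, within a range from 5000 nM to 50000 nM.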

Compound 4, half-maximal inhibitory concentration: 28500 nM
Compound 4: the middle estimate sits 1.8-fold (0.25 log units) below what was measured; the range from low to high includes it.
By their numbers in this assay, from the lowest: compounds 3, 1 and 4 (each within the scatter of the next, the first and the last beyond it). At a limit, above all of these: compound 2.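

In this assay, putting fluoro in place of cyano on the aromatic carbon para to a large group gives a 1.8-fold higher number from compound 1 to compound 4 (0.26 log units; within the scatter), so compound 1 and compound 4 cannot be ordered. This is the first single-place comparison among the compounds shown, and it indicates that, at this position on the shared core, the 4-cyanophenyl and 4-fluorophenyl forms cannot be told apart in this assay, even though the cyano carries a triple bond and a hydrogen-bond acceptor and the fluoro carries neither. Nothing measured here accounts for the step or bears on why these two groups read alike.

What the compounds shown leave open is whether this position stays as undemanding for groups of another kind, such as an amine, a carboxylic acid or a longer alkyl chain, or for a bare hydrogen on that carbon, since one exchange between two small groups sets no limits for the position as a whole. Also open, from the compounds shown here alone, is what a carbonyl in place of the thiocarbonyl would do on its own, with the 4-fluorophenyl or 4-cyanophenyl group held fixed.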